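The source may hold more compounds than are shown below. What is called first, only, known or untested is meant among the compounds shown, and "the series" means these compounds.

Measured in a functional assay on HeLa cells (Homo sapiens) for antiproliferative activity, read by MTT assay, with a stated time of 48 h; on this read-out lower numbers stand for stronger inhibition and higher numbers for weaker inhibition:
- compound 1 `S=c1oc(-c2ccc3c(c2)OCCO3)nn1CN1CCN(C(c2ccccc2)c2ccccc2)CC1`: > 50000 nM (a limit)
- compound 2 `S=c1oc(-c2ccc3c(c2)OCCO3)nn1CN1CCN(c2ccccc2)CC1`: > 50000 nM (a limit)

Compound 2 gives > 50000 nM, which is a limit of the assay and not a number. Among the compounds with values here, the same holds for the whole series so far: the limit of > 50000 nM in this assay, at which 2 of the 2 values shown sit. Within the data shown here, the series therefore offers no numerical value and no measured step.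

Compound 3 `O=[N+]([O-])c1ccc(N2CCN(Cn3nc(-c4ccc5c(c4)OCCO5)oc3=S)CC2)cc1` keeps the rest of compound 2 and changes phenyl to 4-nitrophenyl: nitro in place of hydrogen on an aromatic carbon, (nitro in place of hydrogen on an aromatic carbon). Among the measured compounds shown here, no pair of measured compounds shows what such a change does. In this assay the expected step is small, towards stronger inhibition if it can be seen at all, and a result with no change beyond the scatter would not be surprising. The estimated change is an at least 1.2-fold lower number from compound 2 to compound 3 (0.09 log units; that floor lies within the scatter). Compound 3 is expected to stay close to the limit, and a second limit reading is about as likely as a number. For compound 3 the estimate is 40000 nM, with an expected range from 8000 nM to 100000 nM.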

Compound 3, half-maximal inhibitory concentration: 31700 nM
Compound 3: the middle estimate sits 1.3-fold (0.10 log units) above what was measured; measured number inside the range.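

In this assay, within the data shown here, compound 3 gives 31700 nM, so a number can be read on this series for the first time, with nitro standing on an aromatic carbon of the phenyl ring, para to a large group. The change from phenyl to 4-nitrophenyl amounts to an at least 1.5-fold lower number from compound 2 to compound 3 (0.19 log units; that floor lies within the scatter), which is only a floor and does not by itself establish a real gain over the scatter. Compound 3 is the only compound shown that reads as a number, and the others remain at one limit: the limit of > 50000 nM in this assay, at which 2 of the 3 values shown sit.

Still open, going by these compounds, is whether a methoxy group, a chlorine atom or an amine at the same place on the phenyl ring would also give a number, and whether such a number would sit close to that of compound 3 or well away from it. On these data alone, the true size of the step also remains open, as compound 2 carries only a limit and not a number.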